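The source may hold more compounds than are shown below. What is called first, only, known or untested is meant among the compounds shown, and "the series" means these compounds.

Working notes on the series.

Among the compounds with values here, compound 2 `COc1ccc(CNC(=O)/C(C#N)=C/c2cc(Br)co2)cc1` holds the only number so far in a functional assay on A2780 cells (Homo sapiens) for inhibition, read by MTT assay, with a stated time of 72 h (a lower number here means a stronger inhibitor of growth, a higher number a weaker inhibitor of growth), giving 28000 nM in this assay. Compound 1 `COc1ccc(CNC(=O)/C(C#N)=C/c2ccc[nH]2)cc1` reaches only > 50000 nM in this assay, which is a limit and not a number. That is the limit described as the limit of > 50000 nM in this assay, at which 1 of the 2 values shown sits. Within the data shown here, the single measured step, an at least 1.7-fold lower number from compound 1 to compound 2 (0.25 log units; that floor lies within the scatter), is a floor and nothing more.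

Compound 3 `COc1ccc(CNC(=O)/C(C#N)=C/c2ccc(C)cc2)cc1` differs from compound 2 in one place: 4-methylphenyl in place of 4-bromofuran-2-yl on a double-bonded chain carbon bound to a double-bonded chain carbon. Among the measured compounds shown here, no measured step exchanges the ring on this chain carbon for a six-membered ring of carbon only, so the one step above, itself within the scatter, is the only guide. No step beyond the scatter in either direction is expected for compound 3. The expected value for compound 3 is 30000 nM, with a range from 8000 nM to 100000 nM. The step this estimate implies, a 1.1-fold higher number from compound 2 to compound 3 (0.03 log units; within the scatter), is expected to stay within the scatter.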

Compound 3, concentration for 50% growth inhibition: 33000 nM
Estimate against measurement, compound 3: 1.1-fold (0.04 log units) below; measured number inside the range.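

In this assay, the exchange at this chain carbon of a five-membered aromatic ring with 1 hetero atom for a six-membered aromatic ring of carbon only gives a 1.2-fold higher number from compound 2 to compound 3 (0.07 log units; within the scatter), so 4-bromofuran-2-yl and 4-methylphenyl cannot be told apart here. Neither the ring oxygen nor the bromine is therefore needed for a value of this size, which the earlier pair could not show. The step with 4-methylphenyl in place of 1H-pyrrol-2-yl, an at least 1.5-fold lower number from compound 1 to compound 3 (0.18 log units; that floor lies within the scatter), is only a floor, since compound 1 stands at a limit and not a number: the limit of > 50000 nM in this assay, at which 1 of the 3 values shown sits.

From the compounds shown here alone, whether a dimethylamino group or a carboxylic acid on the ring at this chain carbon would give a step beyond the scatter stays open. Going by these compounds, the nitrile and the amide hydrogen are the same in all three compounds, so their part in these values also stays open.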